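Benzyl in Place of Propyl on a Shared Core

The source may report more compounds than this note shows. Statements on the series, on what has been measured and on what is new or still open speak of the compounds shown alone.

The study so far covers compound 1 `CO[C@@]12CCN(Cc3ccccc3)C[C@H]1[C@H](c1ccc(Cl)cc1Cl)C(C#N)=C(N)O2` and compound 2 `CCCN1CC[C@@]2(OC)OC(N)=C(C#N)[C@@H](c3ccc(C)cc3)[C@@H]2C1`, both measured in a functional assay on trachea (Cavia porcellus); on this read-out lower numbers stand for stronger inhibition and higher numbers for weaker inhibition. In this assay compound 1 gives 18300 nM, and compound 2 gives 21000 nM. Compound 2 thus holds the highest of the two numbers, but its nearest neighbour, compound 1, lies within the scatter of it, so the two cannot be told apart on these data. Compound 3 `CO[C@@]12CCN(Cc3ccccc3)C[C@H]1[C@H](c1ccc(C)cc1)C(C#N)=C(N)O2` has not yet been measured in this assay. It differs from compound 2 by phenyl in place of ethyl on a saturated chain carbon bound to an amine nitrogen in a ring. Going by the values given here, no step between measured compounds isolates this exchange, and compound 1, which also carries the benzyl group, differs from compound 2 in a second place as well. With no shown step to draw on, the move from compound 2 to compound 3 is expected to stay within the scatter, in either direction. Compound 3 is therefore estimated at 17000 nM in this assay, with a range from 6000 nM to 50000 nM. The expected step of a 1.2-fold lower number from compound 2 to compound 3 (0.09 log units; within the scatter) is within the scatter.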

Compound 3, half-maximal inhibitory concentration: 27100 nM
Compound 3: the middle estimate sits 1.6-fold (0.20 log units) below what was measured; measured number inside the range.
By their numbers in this assay, from the lowest: compounds 1, 2 and 3 (each within the scatter of the next).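

The exchange of ethyl for phenyl on a saturated chain carbon bound to an amine nitrogen in a ring, the same difference as propyl to benzyl, now has a step of its own in this assay: the step reads a 1.3-fold higher number from compound 2 to compound 3 (0.11 log units; within the scatter) and so cannot be told from repeat measurements. With the benzyl group in place, 4-methylphenyl in place of 2,4-dichlorophenyl on a saturated ring carbon gives a 1.5-fold higher number from compound 1 to compound 3 (0.17 log units; within the scatter) and likewise does not separate the two compounds. No data at hand offer an explanation for either step.

On these data alone, whether a longer chain or a cyclohexylmethyl group at the first place would move the number beyond the scatter remains open. So does the effect of a methoxy group or an unsubstituted phenyl at the second place.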